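Chain length and cytotoxicity in the benzylamide series

The compounds below may be only part of what the source reports. "The series", "measured", "known", "first", "only" and "open" are said of these compounds alone.

compound 1 `CCCCCCNc1cnc(C(=O)NCc2ccccc2)cn1`: > 100000 nM
compound 2 `CCCCCCNc1nccnc1C(=O)NCc1ccccc1`: 100000 nM
compound 3 `CCCCNc1cncc(C(=O)NCc2ccccc2)n1`: > 100000 nM

In an ADME assay on HEL cells (Homo sapiens) for cytotoxicity, read by microscopy, with a stated time of 6 days (on this read-out higher numbers stand for lower toxicity in this test and lower numbers for higher toxicity in this test), compound 1 stops at the limit > 100000 nM rather than giving a number. Compound 2 gives 100000 nM. Compound 3 also stops at the limit > 100000 nM. For compound 3 only a limit is therefore known, and it sits at the limit of > 100000 nM in this assay, at which 2 of the 3 values shown sit. Compound 4 `CCCCCNc1cncc(C(=O)NCc2ccccc2)n1` differs from compound 3 by methyl in place of hydrogen on a saturated chain carbon, four bonds along the chain from a nitrogen on an aromatic ring. Among the compounds with values here, no step between measured compounds is available for comparison. Because compound 3 stands at the limit of > 100000 nM in this assay, at which 2 of the 3 values shown sit, the change is expected to shift the minimum cytotoxic concentration by nothing beyond the scatter. The estimate for compound 4 is 100000 nM, within 50000 nM to 200000 nM. The expected step is a number no higher from compound 3 to compound 4 (the limit leaves the size open), none beyond the scatter.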

Compound 4, minimum cytotoxic concentration: > 100000 nM
Compound 4 gave a limit, no number; the forecaster's own chance of this, stated with the estimate: 70%; the middle value lies on the limit itself.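

Compound 3 and compound 4 both stop at a limit rather than a number, so no step can be read between them. Where the minimum cytotoxic concentration of either compound lies remains open, as does whether the added methyl shifts it.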